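Swapping benzyl for dimethylamino on a chain

The source may hold more compounds than are shown below. What is called first, only, known or untested is meant among the compounds shown, and "the series" means these compounds.

In a functional assay on U-937 cells (Homo sapiens) (a lower number here means a stronger inhibitor, a higher number a weaker inhibitor), compound 1 `COc1cc(C(=O)NS(=O)(=O)c2ccccc2C)ccc1Cc1cn(C=O)c2ccc(NC(=O)OC3CCCC3)cc12` gives 0.6 nM and compound 2 `CCN(CC)C(=O)n1cc(Cc2ccc(C(=O)NS(=O)(=O)c3ccccc3C)cc2OC)c2cc(NC(=O)OC3CCCC3)ccc21` gives 0.8 nM, which is a 1.3-fold higher number from compound 1 to compound 2 (0.12 log units; within the scatter). Compound 3 `COc1cc(C(=O)NS(=O)(=O)c2ccccc2C)ccc1Cc1cn(C(=O)NCCCc2ccccc2)c2ccc(NC(=O)OC3CCCC3)cc12` gives 0.1 nM, the lowest of the three numbers, and it lies beyond the scatter from both others.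

Compound 4 `COc1cc(C(=O)NS(=O)(=O)c2ccccc2C)ccc1Cc1cn(C(=O)NCCN(C)C)c2ccc(NC(=O)OC3CCCC3)cc12` keeps the core of compound 3 but changes the end of its chain: dimethylamino in place of benzyl on a saturated chain carbon, two bonds along the chain from an amide-type nitrogen. That is dimethylamino in place of benzyl on a saturated chain carbon, two bonds along the chain from an amide-type nitrogen.

For the measured compounds named here, two measured steps bear on this. They are a 6.0-fold lower number from compound 1 to compound 3 (0.78 log units; beyond the scatter) and an 8.0-fold lower number from compound 2 to compound 3 (0.90 log units; beyond the scatter), both modest and both ending at the (3-phenylpropyl)amino group that compound 4 gives up. Going by the values given here, no measured compound carries a chain ending in dimethylamino, so the expectation is loose. Part of that gain is expected to be lost, which points back toward compound 1 and its 0.6 nM value. The expected change is a 4.0-fold higher number from compound 3 to compound 4 (0.60 log units; beyond the scatter) in this estimate, a modest move to a higher number. Compound 4 is estimated at 0.4 nM, within an expected range of 0.1 nM to 1.5 nM.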

Compound 4, half-maximal inhibitory concentration: 0.1 nM
For compound 4 the middle estimate is 4.0-fold (0.60 log units) above the measured one, and the stated range covers the measured number.
By their numbers in this assay, from the lowest: compounds 3 and 4 (each within the scatter of the next); then compounds 1 and 2 (each within the scatter of the next).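

In this assay, the step from benzyl to dimethylamino at this place on the chain gives no change at the digits printed from compound 3 to compound 4 (within the scatter), so the gain seen with compound 3 does not depend on a chain ending in a phenyl ring. The 2-(dimethylamino)ethyl chain keeps that gain against both shorter substituents on the carbonyl carbon, with an 8.0-fold lower number from compound 2 to compound 4 (0.90 log units; beyond the scatter) and a 6.0-fold lower number from compound 1 to compound 4 (0.78 log units; beyond the scatter) as the two steps. Nothing shown here explains why the two chain ends read alike.

The compounds shown leave open how far the result depends on the chain itself, as a shorter or longer chain ending in dimethylamino would show. They also leave open whether the terminal group needs nitrogen at all, which a chain ending in a hydroxyl group or a carboxylic acid would test.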